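Heteroaryl Amide Swap and Expected Mouse Microsomal Stability

The source may report more compounds than this note shows. Statements on the series, on what has been measured and on what is new or still open speak of the compounds shown alone.

Compound 1 `O=C(NCc1ccc(S(=O)(=O)c2cc(F)cc(F)c2)cc1)c1cc2ccncc2o1`: 12%
Compound 2 `O=C(NCc1ccc(S(=O)(=O)N2CCCCC2)cc1)c1cc2cnccc2s1`: "below limit of detection" (no number reported)

In an ADME assay on microsomes from liver (Mus musculus) for metabolic stability, read by LC-MS, with a stated time of 30 min, tested at 1 uM (a lower number here means that less of the compound is left, a higher number that more of the compound is left), compound 1 gives 12%. For compound 2 `O=C(NCc1ccc(S(=O)(=O)N2CCCCC2)cc1)c1cc2cnccc2s1` this assay reports "below limit of detection" (no number reported), with no number attached to the result. Compound 2 therefore stands at no single value in this assay; what its result shows is only that the remaining fraction could not be quantified, whereas compound 1 yields a number. Compound 3 `O=C(NCc1ccc(S(=O)(=O)N2CCCCC2)cc1)c1cc2ccncc2[nH]1` differs from compound 2 in one place: a group of 9 heavy atoms (7 carbon, 2 nitrogen; one five-membered aromatic ring with 1 hetero atom, one six-membered aromatic ring with 1 hetero atom) in place of a group of 9 heavy atoms (7 carbon, 1 nitrogen, 1 sulfur; one five-membered aromatic ring with 1 hetero atom, one six-membered aromatic ring with 1 hetero atom), on a carbonyl carbon. Among the compounds with values here, no measured step exists for this change, so its size in this assay can only be anticipated. Compound 3 is expected to stay low in this assay, with no rise beyond the usual scatter foreseen. Its remaining fraction in this assay is estimated at 8%, within a range from 0% to 25%.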

Compound 3, percent of the compound remaining: "below limit of detection" (no number reported)
The entry for compound 3 holds no number; the estimate stays without a comparison.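

In this assay compound 3 gives "below limit of detection" (no number reported), and compound 2 also has no number, so no step can be read between compound 2 and compound 3. As far as these compounds go, how far the two stand apart in remaining fraction stays open. Nothing available bears on this result.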